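The source may hold more compounds than are shown below. What is called first, only, known or untested is meant among the compounds shown, and "the series" means these compounds.

Notes on the series.

The shared core carries an ester on the saturated ring, and the acyl group on that ester is where the three measured compounds differ. Compound 1 `CCCCCc1ccc(C(=O)O[C@@H]2CCC(NC(=O)[C@H](OC)[C@H](O)[C@@H](O)[C@H](O)/C=C/C(C)(C)C)C(=O)NC2)cc1` gives 20 nM in an in vivo functional assay on the whole organism (MDA-MB-435 cells, Homo sapiens) for antiproliferative activity; on this read-out higher numbers stand for weaker inhibition and lower numbers for stronger inhibition. Compound 2 `CO[C@@H](C(=O)NC1CC[C@@H](OC(=O)Cc2cccnc2)CNC1=O)[C@H](O)[C@@H](O)[C@H](O)/C=C/C(C)(C)C` gives 5850 nM in this assay, and the step of a 290-fold higher number from compound 1 to compound 2 (2.47 log units; beyond the scatter). Compound 3 `CO[C@@H](C(=O)NC1CC[C@@H](OC(=O)C2CCCCC2)CNC1=O)[C@H](O)[C@@H](O)[C@H](O)/C=C/C(C)(C)C` gives 4 nM, the lowest of the three numbers; the step of a 5.0-fold lower number from compound 1 to compound 3 (0.70 log units; beyond the scatter), and the step of a 1500-fold lower number from compound 2 to compound 3 (3.17 log units; beyond the scatter).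

Compound 4 `CO[C@@H](C(=O)NC1CC[C@@H](OC(=O)C2CCCC2)CNC1=O)[C@H](O)[C@@H](O)[C@H](O)/C=C/C(C)(C)C` has not yet been measured. It differs from compound 3 in one place: cyclopentyl in place of cyclohexyl on a carbonyl carbon. Only the cyclohexyl compound 3 bears directly on this change; the steps from compound 1 and compound 2 to compound 3 show that the acyl group on this carbonyl carbon can move the number a great deal, but both involve the removal of an aromatic ring and are not of the same kind as a loss of one ring carbon. Going by the values given here, no measured pair separates a six-membered from a five-membered saturated ring.

The expectation is therefore a step of a 1.5-fold higher number from compound 3 to compound 4 (0.18 log units; within the scatter) in this assay, within the scatter, with the estimate for compound 4 at 6 nM, in the range 2 nM to 20 nM.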

Compound 4, half-maximal inhibitory concentration: 130 nM
Beside the measured number, compound 4's estimate is 22-fold (1.34 log units) below it; the whole stated range lies below it.
By their numbers in this assay, from the lowest: compound 3; then compound 1; then compound 4; then compound 2.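

In this assay, this position proves sensitive even between two saturated carbon rings, neither with hydrogen-bond donors or acceptors: cyclopentyl in place of cyclohexyl gives a 33-fold higher number from compound 3 to compound 4 (1.51 log units; beyond the scatter), whereas every earlier step at this carbonyl carbon involved an aromatic ring. The cyclopentyl ester still improves on the (pyridin-3-yl)methyl ester, with a 45-fold lower number from compound 2 to compound 4 (1.65 log units; beyond the scatter), but it falls behind the 4-pentylphenyl ester, with a 6.5-fold higher number from compound 1 to compound 4 (0.81 log units; beyond the scatter), so the two saturated rings do not group together in the order, with compound 1 lying between them. Nothing shown here accounts for the gap between the six-membered and five-membered rings.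

From the compounds shown here alone, with only these two saturated rings in hand, it remains open whether the number tracks ring size at all, and a cyclobutyl or cycloheptyl group on this carbonyl carbon would extend that comparison in either direction. An open chain such as n-hexyl in the same place would further show whether the ring itself matters or only the carbons it carries.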